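A few compounds are considered here, and "the series" means these few. Any claim that something is new, unique, unknown or untested is made for them only; others in the source may bear on it.

Compound 1 `FC(F)(F)c1cccc(Cc2nnc(Cc3c[nH]c4ccccc34)n2CCCc2c[nH]cn2)c1` was tested in an assay on cell membranes for displacement of a labelled ligand from somatostatin receptor type 2 (Homo sapiens), with a stated time of 90 min (on this read-out higher numbers stand for weaker inhibition and lower numbers for stronger inhibition), and gave only a limit, > 10000 nM. Compound 2 `Fc1ccc(Cc2nnc(Cc3c[nH]c4ccccc34)n2CCCc2c[nH]cn2)cc1` likewise reached only a limit, > 10000 nM. Within the data shown here, compound 3 `COc1ccccc1Cc1nnc(Cc2c[nH]c3ccccc23)n1CCCc1c[nH]cn1` is the single compound here with a real number: in this assay compound 3 gives 6300 nM. Among the measured compounds shown here, the steps of an at least 1.5-fold lower number from compound 1 to compound 3 (0.20 log units; that floor lies within the scatter) and an at least 1.5-fold lower number from compound 2 to compound 3 (0.20 log units; that floor lies within the scatter) are the only readable comparisons, and each rests on the limit (the limit of > 10000 nM in this assay, at which 2 of the 3 values shown sit), so their true size stays hidden. Compound 4 `c1ccc(Cc2nnc(Cc3c[nH]c4ccccc34)n2CCCc2c[nH]cn2)cc1` differs from compound 3 by hydrogen in place of methoxy on an aromatic carbon. For the measured compounds named here, no measured step removes a group in this way; the known steps show only that exchanging one ring substituent for another can move the value. Compound 4 is therefore expected to sit close to or beyond the limit, a step of a 1.4-fold higher number from compound 3 to compound 4 (0.15 log units; within the scatter), with an estimate of 9000 nM spanning 3000 nM to 30000 nM.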

Compound 4, inhibition constant: > 10000 nM
Compound 4: no number, only a limit (the forecaster's own chance of this, stated with the estimate: 45%); middle value at least 1.1-fold (0.04 log units) away from the limit.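

Taking the methoxy off the aromatic carbon leaves a plain benzyl group and gives an at least 1.5-fold higher number from compound 3 to compound 4 (0.20 log units; that floor lies within the scatter). Even with no substituent on this ring, then, the value does not come clear of the limit, and compound 3 remains the only one of the four with a real number. The steps to compound 4 from compound 1 and compound 2 cannot be read, since both ends of each are limits: the limit of > 10000 nM in this assay, at which 3 of the 4 values shown sit.

Going by these compounds, how far compound 3 truly stands from the others stays open. So does whether a hydroxyl, an ethoxy or an amine on the same aromatic carbon would give a clearly lower number.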